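Swapping a Benzamide Ring for an Unsaturated Ester Chain

This account rests on a few compounds, and the source may have more. Where it says the series, first, only, none or still open, it means among the compounds named here.

Of the compounds shown here, three built on one shared core have been tested in a functional assay on LNCaP cells (Homo sapiens) for antiproliferative activity, read by CCK-8 assay, with a stated time of 6 days; a higher number here means a weaker inhibitor, a lower number a stronger inhibitor. Compound 1 `CC(=O)c1cc(C(=O)N[C@@H](C)Cn2ccc(-c3cc(F)c(C#N)c(Cl)c3)n2)n[nH]1` gives 1100 nM. Compound 2 `C[C@@H](Cn1ccc(-c2ccc(C#N)c(Cl)c2)n1)NC(=O)c1ccccc1` gives 1830 nM, and compound 3 `CC(O)c1ccc(C(=O)N[C@@H](C)Cn2ccc(-c3ccc(C#N)c(Cl)c3)n2)cc1` gives 3690 nM. Compound 2 therefore sits between the numbers of compound 1 and compound 3, and both of those gaps fall within the scatter. Going by the values given here, the one step resolved so far, a 2.0-fold higher number from compound 2 to compound 3 (0.30 log units; within the scatter), touched only the outer aromatic ring and did not move the number beyond the scatter.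

Compound 4 `COC(=O)/C=C/C(=O)N[C@@H](C)Cn1ccc(-c2ccc(C#N)c(Cl)c2)n1` is the compound not yet tested. It differs from compound 2 by 2-(methoxycarbonyl)ethenyl in place of phenyl on a carbonyl carbon. Among the compounds with values here, no measured step alters this part of the molecule, so the sole step in hand speaks to it only indirectly: it shows that one alteration at the far edge of the same amide leaves the number essentially unchanged. Carrying that over, the step of a 1.4-fold higher number from compound 2 to compound 4 (0.14 log units; within the scatter) is expected to be modest, leaning toward a higher number. Compound 4 is accordingly estimated at 2500 nM, with a range from 800 nM to 8000 nM.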

Compound 4, half-maximal inhibitory concentration: 2460 nM
For compound 4 the middle estimate is 1.0-fold (0.01 log units) above the measured one; the measured number falls inside the stated range.
By their numbers in this assay, from the lowest: compounds 1, 2, 4 and 3 (each within the scatter of the next, the first and the last beyond it).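

In this assay the step of a 1.3-fold higher number from compound 2 to compound 4 (0.13 log units; within the scatter) replaces the phenyl on the carbonyl carbon with 2-(methoxycarbonyl)ethenyl, and the number stays within the scatter even though the aromatic ring is gone and an open chain with two hydrogen-bond acceptors stands in its place. The earlier step altered only a group on that ring, whereas this result shows that the ring itself can be exchanged here without a change beyond the scatter, and the step of a 1.5-fold lower number from compound 3 to compound 4 (0.18 log units; within the scatter) is also within the scatter. Nothing available explains this outcome. On these data alone, it remains open whether a carboxylic acid in place of the methyl ester, or a saturated chain in place of the double bond, would keep the number within the scatter. As far as these compounds go, a longer chain or an amine at the end of the chain is equally open.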